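A few compounds are considered here, and "the series" means these few. Any claim that something is new, unique, unknown or untested is made for them only; others in the source may bear on it.

Compound 1, `O=C(/C=C/c1ccc(O)c(O)c1)CC(=O)/C=C/c1cccc(O)c1O`: 19000 nM
Compound 2, `O=C(/C=C/c1ccc(O)cc1)CC(=O)/C=C/c1cccc(O)c1O`: 27000 nM
Compound 3, `O=C(/C=C/c1cccc(O)c1)CC(=O)/C=C/c1cc(O)ccc1O`: 88000 nM

Of the compounds shown here, three have been measured in a functional assay, with a stated time of 30 min; a higher number here means a weaker inhibitor, a lower number a stronger inhibitor. Compound 1 gives 19000 nM, compound 2 gives 27000 nM, and compound 3 gives 88000 nM. Compound 3 stands highest of the three; its nearest neighbour is compound 2, and both that gap and the gap to compound 1 lie beyond the scatter.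

Compound 1 and compound 2 differ in one place, (hydroxy in place of hydrogen on an aromatic carbon), and the step is a 1.4-fold lower number from compound 2 to compound 1 (0.15 log units; within the scatter). Compound 2 and compound 3 have the same atoms joined differently; the difference between the two cores is not broken down here.

The unmeasured compound 4, `O=C(/C=C/c1cc(O)ccc1O)CC(=O)/C=C/c1cc(O)ccc1O`, arises from compound 3 by hydroxy in place of hydrogen on an aromatic carbon. This is the same kind of change as from compound 2 to compound 1, but the surroundings are not identical: in the earlier pair the entering hydroxy is ortho to a hydroxy group and meta to a large group, whereas here it is ortho to a large group and para to a hydroxy group. Because a 1.4-fold lower number from compound 2 to compound 1 (0.15 log units; within the scatter) lay within the scatter, the expected step for compound 4 is also small, a 1.3-fold lower number from compound 3 to compound 4 (0.10 log units; within the scatter). The estimate rests on a single precedent at a different place, so the range is kept wide. Compound 4 is therefore expected at 70000 nM, between 30000 nM and 160000 nM.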

Compound 4, half-maximal inhibitory concentration: 57000 nM
Beside the measured number, compound 4's estimate is 1.2-fold (0.09 log units) above it; the range from low to high includes it.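

In this assay, hydroxy in place of hydrogen on an aromatic carbon, which turns the 3-hydroxyphenyl of compound 3 into the 2,5-dihydroxyphenyl of compound 4, gives a 1.5-fold lower number from compound 3 to compound 4 (0.19 log units; within the scatter). Set beside the earlier case of this change, the new step agrees with it, and the change carries from one core to the other without a detectable difference in size: the same change on two cores in this assay, a 1.4-fold lower number (0.15 log units; within the scatter) from compound 2 to compound 1 and a 1.5-fold lower number (0.19 log units; within the scatter) from compound 3 to compound 4, 1.1-fold (0.04 log units) apart, within the scatter of two such steps This does not show that the added hydroxy lowers the number on either core, since each step on its own lies within the scatter, and it rests on only two pairs in which the entering hydroxy stands at different places, so it gives no rule for other cores or other places in the series.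

The compounds shown carry only hydroxy groups on their aromatic rings, which leaves open whether a methoxy group, a fluorine atom, an amine or a carboxylic acid at the same place would give a step beyond the scatter. They also leave open what a longer chain between the two aromatic rings, or a replacement of the two carbonyl groups in that chain, would do to the number.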